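Oxolan-3-yl in place of 2-hydroxy-2-methylpropyl: expected shift

The source may hold more compounds than are shown below. What is called first, only, known or untested is meant among the compounds shown, and "the series" means these compounds.

Measured in an assay on isolated protein for inhibition of Leucine-rich repeat serine/threonine-protein kinase 2 variant G2019S (Homo sapiens), read by TR-FRET and LanthaScreen, with stated times of 50 min and 30 min, in the presence of a further agent that is not named here; a higher number here means a weaker inhibitor, a lower number a stronger inhibitor:
compound 1 `C[C@@H]1CCCN1c1c(C#N)c2c(N)nc(Nc3ccn(C)n3)cc2n1C`: 206 nM
compound 2 `Cc1c(Nc2nc(N)c3c(C#N)c(N4CCC[C@H]4C)n(C)c3n2)cnn1CC(C)(C)O`: 35 nM
compound 3 `CN(C)c1c(C#N)c2c(N)ncnc2n1C`: 3760 nM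

Compound 2 holds the lowest number of the three in this assay. Compound 1 sits higher, and the gap is beyond the usual scatter; compound 3, with the smallest substitution pattern on the shared core, sits highest by a wide margin. Among the compounds with values here, no pair of these three differs in a single place, so no single-point step is available from the measured set.

Compound 4 `Cc1c(Nc2nc(N)c3c(C#N)c(N4CCC[C@H]4C)n(C)c3n2)cnn1[C@@H]1CCOC1` is the next compound. It differs from compound 2 in one place: oxolan-3-yl in place of 2-hydroxy-2-methylpropyl on an aromatic nitrogen. The group that leaves carries a hydrogen-bond donor; the group that enters has none and is a ring with a defined stereocentre. Within the data shown here, no measured pair shows the effect of such a change on this core, so the direction is open. The expectation is a step from compound 2 to compound 4 of a 1.1-fold higher number from compound 2 to compound 4 (0.06 log units; within the scatter), within the usual scatter. Compound 4 is estimated at 40 nM, in the range 15 nM to 110 nM.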

Compound 4, half-maximal inhibitory concentration: 12 nM
Beside the measured number, compound 4's estimate is 3.3-fold (0.52 log units) above it; the whole stated range lies above it.
By their numbers in this assay, from the lowest: compound 4; then compound 2; then compound 1; then compound 3.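

Within the data shown here, on the aromatic nitrogen, oxolan-3-yl in place of 2-hydroxy-2-methylpropyl gives a 2.9-fold lower number from compound 2 to compound 4 (0.46 log units; beyond the scatter) in this assay, the first single-place comparison. The heavy-atom count at this place stays the same while an open chain with a hydrogen-bond donor gives way to a ring with none, so in this pair a hydrogen-bond donor on this group is not needed for the lower number. The compounds at hand offer no measurement that explains the step.

Still open, going by these compounds, is whether the step follows from the ring, its stereocentre or the loss of the hydroxyl; a cyclopentyl ring, the opposite oxolan-3-yl stereoisomer or a 2-methoxy-2-methylpropyl chain on the same nitrogen would separate these. On these data alone, whether the step carries over to other groups elsewhere on the shared core also remains unknown.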